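The compounds below may be only part of what the source reports. "The series", "measured", "known", "first", "only" and "open" are said of these compounds alone.

The measurements here come from an ADME assay on Huh-7 cells (Homo sapiens) for cytotoxicity; on this read-out lower numbers stand for higher toxicity in this test and higher numbers for lower toxicity in this test. Within the data shown here, compound 1 `Cc1ccccc1CNc1nn(-c2ccc(F)cc2F)cc1CNCCN1CCN(C)CC1` is one of two compounds tested so far. In this assay compound 1 gives only a limit, > 20000 nM, and not a number. Compound 2 `Cc1ccccc1-c1nn(-c2ccc(OC(F)(F)F)cc2)cc1CNCCN1CCN(C)CC1` differs from compound 1 in more than one place, and in this assay compound 2 gives 17000 nM. Both results lie at the weakly toxic end of the scale, and the result for compound 1 rests at the limit of > 20000 nM in this assay, at which 1 of the 2 values shown sits.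

The step of interest leads from compound 1 to compound 3 `CN1CCN(CCNCc2cn(-c3ccc(F)cc3F)nc2Cc2ccccc2)CC1`, which has not yet been measured. The change is benzyl in place of (2-methylbenzyl)amino on an aromatic carbon. Among the measured compounds shown here, no pair of measured compounds that differ in one place is available to show what such a change does, so the expectation rests on compound 1 alone. For compound 3 the step of a number no higher from compound 1 to compound 3 (the limit leaves the size open) is expected to stay within the usual scatter of this assay, with no clear direction. The half-maximal cytotoxic concentration of compound 3 is therefore estimated at 20000 nM, in a range from 8000 nM to 50000 nM, with a fair chance that only a limit is again reported.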

Compound 3, half-maximal cytotoxic concentration: > 20000 nM
Compound 3 ended at the assay's limit; the forecaster's own chance of this, stated with the estimate: 55%; the middle value sits exactly at the limit.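

In this assay compound 3 gives > 20000 nM, which is a limit and not a number. Compound 1 also gives only a limit, so no step can be read between compound 1 and compound 3. The compounds shown leave open what benzyl in place of (2-methylbenzyl)amino does to the half-maximal cytotoxic concentration.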